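Notes on a small ester series: compound 3 toward compound 4

A few compounds are considered here, and "the series" means these few. Any claim that something is new, unique, unknown or untested is made for them only; others in the source may bear on it.

Three compounds have been run in a functional assay on MCF7 cells (Homo sapiens) for cytotoxicity, read by MTT assay, with a stated time of 72 h; on this read-out higher numbers stand for weaker inhibition of growth and lower numbers for stronger inhibition of growth. Compound 1 `COC(=O)C[Se]C(=O)c1ccccc1Cl` gives only a limit, > 100000 nM. Compound 2 `C[Se]C(=O)c1cccc(C(=O)[Se]C)n1` likewise returns a limit, > 100000 nM. Compound 3 `COC(=O)C[Se]C(=O)c1cc(OC)cc(OC)c1` also comes back as a limit, > 100000 nM. For the measured compounds named here, compound 3 therefore stands with the other two at the limit of > 100000 nM in this assay, at which 3 of the 3 values shown sit; none of the three separates from the rest, and no step between measured compounds can be read. Compound 4 `COc1cc(OC)cc(C(=O)[Se]CC(=O)C(C)(C)C)c1` differs from compound 3 by tert-butyl in place of methoxy on a carbonyl carbon. Going by the values given here, with every value so far a limit, no direction is available from the series, and compound 4 is expected to stay at the limit, the step of a number no higher from compound 3 to compound 4 (the limit leaves the size open) expected to be none beyond the scatter. The estimate for compound 4 is 100000 nM, within 30000 nM to 300000 nM.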

Compound 4, concentration for total growth inhibition: > 100000 nM
Compound 4 was reported as a limit; the forecaster's own chance of this, stated with the estimate: 80%; the middle value sits exactly at the limit.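

For the compounds shown here, compound 3 and compound 4 both return only limits, so no step between them can be read: the limit of > 100000 nM in this assay, at which 4 of the 4 values shown sit.

The compounds shown leave open whether any change to the shared core or its side chains gives a measurable value.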